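This account rests on a few compounds, and the source may have more. Where it says the series, first, only, none or still open, it means among the compounds named here.

Working notes on the series. Compound 1 `Cc1ccc(Nc2ncc3c(n2)N(C)C(=O)N(c2cc(NC(=O)c4cccc(C(F)(F)F)c4)ccc2C)C3)cc1` in an ADME assay on BaF3 cells (Mus musculus) for antiproliferative activity, read by CellTiter-Glo and CCK-8 assay, with a stated time of 72 h (a higher number here means a weaker inhibitor of growth, a lower number a stronger inhibitor of growth), gives 8000 nM. Compound 2 `Cc1ccc(Nc2ncc3c(n2)N(C)C(=O)N(c2cc(NC(=O)c4cccc(-c5ccccc5)c4)ccc2C)C3)cc1N` in this assay reaches only > 10000 nM, which is a limit of the assay and not a number, so for compound 2 only a limit is known. That puts compound 2 at the limit of > 10000 nM in this assay, at which 1 of the 2 values shown sits. Compound 1 and compound 2 differ in more than one place, so their two values show only that both lie toward the weak end of the scale. Compound 3 `Cc1cccc(C(=O)Nc2ccc(C)c(N3Cc4cnc(Nc5ccc(C)c(N)c5)nc4N(C)C3=O)c2)c1` is the next case and has not yet been measured in this assay. Against compound 2 the change is methyl in place of phenyl on an aromatic carbon, which cut one bond further out reads as 3-methylphenyl in place of 3-phenylphenyl. Among the measured compounds shown here, with compound 2 standing at a limit, no measured step sets the size of what this change should bring; the step expected from compound 2 to compound 3 in this assay is an at least 1.1-fold lower number from compound 2 to compound 3 (0.04 log units; that floor lies within the scatter), nothing beyond the usual scatter in either direction. Compound 1, which carries a trifluoromethyl at the same place but lacks the amino group, gives 8000 nM and frames the range. Compound 3 is estimated at 9000 nM, within 3000 nM to 25000 nM.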

Compound 3, concentration for 50% growth inhibition: > 10000 nM
Compound 3: no number, only a limit; the forecaster's own chance of this, stated with the estimate: 40%; middle value at least 1.1-fold (0.04 log units) from the limit.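

Compound 3 in this assay gives > 10000 nM, a limit of the assay and not a number. Compound 2 stands at a limit as well, so no step can be read between compound 2 and compound 3: the limit of > 10000 nM in this assay, at which 2 of the 3 values shown sit. The compounds shown leave open whether 3-methylphenyl and 3-phenylphenyl differ at all in this assay.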